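Aryl swap on the benzylamide of compound 3

The source may report more compounds than this note shows. Statements on the series, on what has been measured and on what is new or still open speak of the compounds shown alone.

Among the measured compounds shown here, compound 3 `Cc1ccc(CNC(=O)c2cccc(C(C)Oc3ccnc(Nc4cnn(CC(C)(C)O)c4)c3)c2)cc1` gives 49700 nM in a functional assay on HCC78 cells (Homo sapiens) for antiproliferative activity, read by MTT assay, with a stated time of 48 h (on this read-out lower numbers stand for stronger inhibition and higher numbers for weaker inhibition), the highest of the three numbers measured so far. Compound 1 `CC(Oc1ccnc(Nc2cnn(C3CCN(C)CC3)c2)c1)c1cccc(C(=O)NCc2ccc(Cl)c(C(F)(F)F)c2)c1` gives 7300 nM and compound 2 `CC(Oc1ccnc(NN2CCN(C)CC2)c1)c1cccc(C(=O)NCc2ccc(Cl)c(C(F)(F)F)c2)c1` gives 23500 nM; both carry the 4-chloro-3-(trifluoromethyl)benzyl amide, whereas compound 3 carries a 4-methylbenzyl amide and a different substituent on the pyrazole nitrogen. For the measured compounds named here, the only single-point step measured, a 3.2-fold higher number from compound 1 to compound 2 (0.51 log units; beyond the scatter), concerns the amine on the shared core and not the amide aryl, so it does not bear on the change at hand.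

Compound 4 `CC(Oc1ccnc(Nc2cnn(CC(C)(C)O)c2)c1)c1cccc(C(=O)NCc2ccc(Cl)c(C(F)(F)F)c2)c1` keeps the pyrazole substituent of compound 3 and changes the amide end: 4-chloro-3-(trifluoromethyl)phenyl in place of 4-methylphenyl on a saturated chain carbon bound to an amide-type nitrogen. Going by the values given here, no measured step isolates this change; the values of compound 1 and compound 2 show only that the entering group is compatible with lower numbers than compound 3 gives. The step of a 3.1-fold lower number from compound 3 to compound 4 (0.49 log units; beyond the scatter) is therefore expected to be modest toward lower numbers, with wide uncertainty. Compound 4 is estimated at 16000 nM, within a range of 5000 nM to 45000 nM.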

Compound 4, half-maximal inhibitory concentration: > 100000 nM
Compound 4 was reported as a limit (the forecaster's own chance of this, stated with the estimate: 5%); middle value at least 6.2-fold (0.79 log units) away from the limit.
By their numbers in this assay, from the lowest: compound 1; then compound 2; then compound 3. At a limit, above all of these: compound 4.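

Compound 4 is reported only as a limit in this assay, the only one in the series: the limit of > 100000 nM in this assay, at which 1 of the 4 values shown sits. Going by these compounds, at the amide end, 4-chloro-3-(trifluoromethyl)phenyl in place of 4-methylphenyl gives an at least 2.0-fold higher number from compound 3 to compound 4 (0.30 log units; that floor lies within the scatter); that floor lies within the scatter, so the direction is suggested but the size of the change stays unknown. With the 4-chloro-3-(trifluoromethyl)benzyl amide held fixed, the group on the other end of the molecule still moves the read-out, with an at least 4.2-fold higher number from compound 2 to compound 4 (0.62 log units; beyond the scatter) and an at least 13-fold higher number from compound 1 to compound 4 (1.13 log units; beyond the scatter), so this amide does not by itself give the lower numbers of compound 1 and compound 2.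

On these data alone, the true position of compound 4 remains open, as does the effect of the aryl swap with 1-methylpiperidin-4-yl held in place. Also open, as far as these compounds go, is whether a 4-chlorobenzyl amide, or a 2-aminoethyl group on the aromatic nitrogen, would give a number under the limit.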